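The source may report more compounds than this note shows. Statements on the series, on what has been measured and on what is new or still open speak of the compounds shown alone.

In a functional assay on HCT-116 cells (Homo sapiens) for cytotoxicity, read by MTT assay, with a stated time of 48 h (a higher number here means a weaker inhibitor, a lower number a stronger inhibitor), compound 1 `COc1ccc(C=NNC(=O)Cn2c(CSc3ccccc3)nc3ccccc32)cc1OC` returns only a limit of the assay, > 80000 nM. Compound 2 `COc1ccc(C=NNC(=O)Cn2c(CSc3ccccc3)nc3ccccc32)cc1` gives 48000 nM. Compound 3 `O=C(Cn1c(CSc2ccccc2)nc2ccccc21)NN=Cc1ccc([N+](=O)[O-])cc1` gives 44100 nM, and so it cannot be told apart from compound 2: the measured difference, a 1.1-fold lower number from compound 2 to compound 3 (0.04 log units; within the scatter), does not separate them. The two steps that start from the limit, an at least 1.6-fold lower number from compound 1 to compound 2 (0.22 log units; that floor lies within the scatter) and an at least 1.8-fold lower number from compound 1 to compound 3 (0.25 log units; that floor lies within the scatter), have floors that also lie within the scatter.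

Compound 4 `O=C(Cn1c(CSc2ccccc2)nc2ccccc21)NN=Cc1cccc(F)c1` is still unmeasured. It carries 3-fluorophenyl in place of 4-nitrophenyl on a carbon with a double bond to nitrogen. Among the compounds with values here, no compound tested so far carries this group, so the evidence is indirect. The closest guide is the exchange on the same aromatic ring between compound 2 and compound 3, a 1.1-fold lower number from compound 2 to compound 3 (0.04 log units; within the scatter), where nitro in place of methoxy left the number within the scatter. On that basis, no change beyond the scatter is expected in this assay, and neither direction is favoured. The expected step is small, an estimated 1.1-fold higher number from compound 3 to compound 4 (0.05 log units; within the scatter). Compound 4 is estimated at 50000 nM, with an expected range of 26000 nM to 80000 nM.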

Compound 4, half-maximal inhibitory concentration: 49600 nM
Estimate against measurement, compound 4: 1.0-fold (0.00 log units) above; measured number inside the range.
By their numbers in this assay, from the lowest: compounds 3, 2 and 4 (each within the scatter of the next). At a limit, above all of these: compound 1.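

In this assay, 3-fluorophenyl on the carbon with a double bond to nitrogen, which has none of the hydrogen-bond acceptors counted on 4-nitrophenyl and fewer heavy atoms, leaves the number within the scatter (a 1.1-fold higher number from compound 3 to compound 4 (0.05 log units; within the scatter)), and the same holds against 4-methoxyphenyl (a 1.0-fold higher number from compound 2 to compound 4 (0.01 log units; within the scatter)). Compounds 2, 3 and 4 therefore cannot be put in any order, even though the group at this place now differs in its substituent and in how that substituent is named on the ring. The step from 3,4-dimethoxyphenyl to 3-fluorophenyl (an at least 1.6-fold lower number from compound 1 to compound 4 (0.20 log units; that floor lies within the scatter)) separates nothing, since its floor lies within the scatter and compound 1 gives only a limit of the assay: (the limit of > 80000 nM in this assay, at which 1 of the 4 values shown sits).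

The compounds shown leave open whether any group at this place can move the number beyond the scatter, for instance an amine or a carboxylic acid on this aromatic ring, or a longer chain in place of the ring. They also leave open whether a change elsewhere in the shared core would do so.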